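Furan-2-yl in place of iodo: working notes

This account rests on a few compounds, and the source may have more. Where it says the series, first, only, none or still open, it means among the compounds named here.

In a functional assay on L1210 cells (Mus musculus) for antiproliferative activity, read by cell counting, with a stated time of 48 h (on this read-out lower numbers stand for stronger inhibition and higher numbers for weaker inhibition), compound 1 (`C#C[C@@]1(O)[C@@H](CO)O[C@@H](n2cc(F)c3c(N)ncnc32)[C@@H]1O`) gives 35 nM, compound 2 (`C#C[C@@]1(O)[C@@H](CO)O[C@@H](n2cc(Br)c3c(N)ncnc32)[C@@H]1O`) gives 28 nM and compound 3 (`C#C[C@@]1(O)[C@@H](CO)O[C@@H](n2cc(I)c3c(N)ncnc32)[C@@H]1O`) gives 56 nM, so compound 3 stands within the scatter of both others. Compound 4 (`C#C[C@@]1(O)[C@@H](CO)O[C@@H](n2cc(-c3ccco3)c3c(N)ncnc32)[C@@H]1O`) carries furan-2-yl in place of iodo on an aromatic carbon. The nearest evidence is the swaps among fluoro, bromo and iodo: a 1.3-fold lower number from compound 1 to compound 2 (0.10 log units; within the scatter), a 1.6-fold higher number from compound 1 to compound 3 (0.20 log units; within the scatter) and a 2.0-fold higher number from compound 2 to compound 3 (0.30 log units; within the scatter), all within the scatter. None of these steps brings in a ring, so they guide this change only loosely. A modest move to a higher number is expected in this assay, and the estimated step is a 2.0-fold higher number from compound 3 to compound 4 (0.29 log units; within the scatter). The estimate for compound 4 is 110 nM, with an expected range of 25 nM to 600 nM.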

Compound 4, half-maximal inhibitory concentration: 30000 nM
Compound 4: middle estimate off by 270-fold (2.44 log units), on the low side, outside the stated range (above it).
By their numbers in this assay, from the lowest: compounds 2, 1 and 3 (each within the scatter of the next); then compound 4.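

In this assay, for the compounds shown here, fluoro, bromo and iodo on this aromatic carbon all sit within the scatter of one another, but furan-2-yl, the only one of the four groups that brings in a ring, gives a 540-fold higher number from compound 3 to compound 4 (2.73 log units; beyond the scatter) and a 1100-fold higher number from compound 2 to compound 4 (3.03 log units; beyond the scatter) and an 860-fold higher number from compound 1 to compound 4 (2.93 log units; beyond the scatter). The swaps among the halogens therefore gave no sign that this position could respond so strongly to a change of group. Nothing available here explains the size of these steps. From the compounds shown here alone, it remains open whether the loss belongs to furan-2-yl itself or extends to other groups larger than a halogen. A phenyl ring, an ethyl chain or an amine at this place would help separate those readings.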